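The source may hold more compounds than are shown below. What is called first, only, known or untested is meant among the compounds shown, and "the series" means these compounds.

Compound 1 `C=CC[C@H]1C[C@]2([C@@H](C)Cc3ccc(OC)c(OC)c3)OCOC2=CC1=O` gives the lowest number of the three measured in a functional assay on M14 cells (Homo sapiens) for antiproliferative activity, with a stated time of 72 h (a lower number here means a stronger inhibitor, a higher number a weaker inhibitor), where compound 1 gives 110 nM. Compound 2 `C=CC[C@H]1C[C@]2(CCc3ccc(OC)c(OC)c3)OCOC2=CC1=O` gives 2000 nM in this assay, and compound 3 `C=CC[C@H]1C[C@]2([C@@H](C)Cc3cccc(OC)c3)OCOC2=CC1=O` gives 8800 nM. The two measured steps are both large: an 18-fold higher number from compound 1 to compound 2 (1.26 log units; beyond the scatter), and an 80-fold higher number from compound 1 to compound 3 (1.90 log units; beyond the scatter). Compound 4 `C=CC[C@H]1C[C@]2([C@@H](C)Cc3ccc(OC)c(C(=O)NC)c3)OCOC2=CC1=O` has not been measured. It differs from compound 1 in one place: methylcarbamoyl in place of methoxy on an aromatic carbon. The step that bears on this most directly is the loss of the same methoxy, since an 80-fold higher number from compound 1 to compound 3 (1.90 log units; beyond the scatter) shows how much the number rises when that group is removed entirely. Compound 4 keeps a group at that position, with a hydrogen-bond acceptor and a donor, so the change is expected to cost less than the outright removal, but still to push the number upward beyond the scatter. The expected step is a 9.1-fold higher number from compound 1 to compound 4 (0.96 log units; beyond the scatter). For compound 4 the estimated value in this assay is 1000 nM, with a range from 200 nM to 6000 nM.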

Compound 4, half-maximal inhibitory concentration: 1400 nM
Beside the measured number, compound 4's estimate is 1.4-fold (0.15 log units) below it; measured number inside the range.
By their numbers in this assay, from the lowest: compound 1; then compounds 4 and 2 (each within the scatter of the next); then compound 3.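

Within the data shown here, the step of a 13-fold higher number from compound 1 to compound 4 (1.10 log units; beyond the scatter) in this assay is the first reading at this aromatic carbon, the one ortho to a methoxy group and meta to a large group. Compound 3 keeps its methoxy at this carbon and lacks the other one, so the earlier step concerned a different place, and compound 3 and compound 4 cannot be compared directly. The new step shows that this methoxy cannot be exchanged for methylcarbamoyl without a large rise in the number, so a change at either methoxy carbon has now given a large rise, though the two changes are different. Nothing measured here accounts for this rise. The compounds shown do not separate the loss of the methoxy from the arrival of methylcarbamoyl, and a hydroxyl or an unsubstituted carboxamide at this carbon would help to do so.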